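A few compounds are considered here, and "the series" means these few. Any claim that something is new, unique, unknown or untested is made for them only; others in the source may bear on it.

Working notes on the amide series. All four compounds share one core, with a nitrile and an amide-bearing side chain; they differ only in the group on the carbonyl carbon. Compound 1 `CN1[C@@H]2c3[nH]c4ccccc4c3C[C@H]1[C@H](C#N)N1[C@@H](CNC(=O)c3ccc(F)cc3)c3[nH]c4ccccc4c3C[C@@H]21` carries 4-fluorophenyl there, and in a functional assay on HCT-116 cells (Homo sapiens) for cytotoxicity, read by MTT assay, with a stated time of 72 h (on this read-out higher numbers stand for weaker inhibition and lower numbers for stronger inhibition), compound 1 gives 140 nM. Compound 2 `CCc1ccc(C(=O)NC[C@H]2c3[nH]c4ccccc4c3C[C@H]3[C@H]4c5[nH]c6ccccc6c5C[C@@H]([C@H](C#N)N23)N4C)cc1` carries 4-ethylphenyl, and in this assay compound 2 gives 100 nM; the step is a 1.4-fold lower number from compound 1 to compound 2 (0.15 log units; within the scatter). Compound 3 `CN1[C@@H]2c3[nH]c4ccccc4c3C[C@H]1[C@H](C#N)N1[C@@H](CNC(=O)c3ccc4ccccc4c3)c3[nH]c4ccccc4c3C[C@@H]21` carries naphthalen-2-yl, and in this assay compound 3 gives 420 nM, the highest of the three numbers: a 3.0-fold higher number from compound 1 to compound 3 (0.48 log units; beyond the scatter) and a 4.2-fold higher number from compound 2 to compound 3 (0.62 log units; beyond the scatter). Compound 4 `CN1[C@@H]2c3[nH]c4ccccc4c3C[C@H]1[C@H](C#N)N1[C@@H](CNC(=O)/C=C/c3cccc(C(F)(F)F)c3)c3[nH]c4ccccc4c3C[C@@H]21` differs from compound 3 by 2-(3-(trifluoromethyl)phenyl)ethenyl in place of naphthalen-2-yl on a carbonyl carbon. The two steps that bear on this both run from a single six-membered aromatic ring to the bicyclic group and both rose beyond the scatter. Among the measured compounds shown here, compound 4 returns to a single ring but adds an ethenyl bridge, for which no measured step exists, so the direction is read from the two steps above only. The step from compound 3 is expected to be a 1.7-fold lower number from compound 3 to compound 4 (0.23 log units; within the scatter). The estimate for compound 4 is 250 nM, in the range 80 nM to 800 nM.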

Compound 4, half-maximal inhibitory concentration: 610 nM
For compound 4 the middle estimate is 2.4-fold (0.39 log units) below the measured one; the measured number falls inside the stated range.
By their numbers in this assay, from the lowest: compounds 2 and 1 (each within the scatter of the next); then compounds 3 and 4 (each within the scatter of the next).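

In this assay, the step of a 1.5-fold higher number from compound 3 to compound 4 (0.16 log units; within the scatter) places 2-(3-(trifluoromethyl)phenyl)ethenyl and naphthalen-2-yl on a level at this carbonyl carbon. Against the other two groups the number rises, with a 6.1-fold higher number from compound 2 to compound 4 (0.79 log units; beyond the scatter) and a 4.4-fold higher number from compound 1 to compound 4 (0.64 log units; beyond the scatter), so having one six-membered aromatic ring instead of two does not by itself keep the number low, which compounds 1, 2 and 3 alone could not show. Nothing available gives a reason for these differences.

As far as these compounds go, compound 4 differs from compounds 1 and 2 in both the ethenyl bridge and the trifluoromethyl group, so the share of each in the rise stays open. Also open, from the compounds shown here alone, is how an unsubstituted 2-phenylethenyl group, a cyclohexyl ring or a phenyl ring carrying an amine would read at this carbonyl carbon.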